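Configuration swap at the saturated ring: compound 3 to compound 4

The source may hold more compounds than are shown below. What is called first, only, known or untested is meant among the compounds shown, and "the series" means these compounds.

Values in a physicochemical assay for solubility, read by HPLC, using the shake flask method, in phosphate buffer, with a stated time of 20 h, at pH 6.5 (a lower number here means a less soluble compound, a higher number a more soluble compound), so far:
- compound 1 `Fc1ccc(-c2nc3c(C4CCNCC4)nccc3[nH]2)cc1F` gives 200000 nM here
- compound 2 `CN1CCN(C2CCN(c3nccc4[nH]c(-c5cccc(OC(F)(F)F)c5)nc34)CC2)CC1` gives 190000 nM here
- compound 3 `CN1CCN([C@H]2CC[C@@H](Nc3nccc4[nH]c(-c5cc(F)cc(F)c5)nc34)CC2)CC1` gives 200000 nM here

Compound 3 (200000 nM) stands level with compound 1 at the digits shown, and compound 2 (190000 nM) lies within the scatter of both. Compound 4 `CN1CCN([C@H]2CC[C@H](Nc3nccc4[nH]c(-c5cc(F)cc(F)c5)nc34)CC2)CC1` comes from compound 3 by one change, (the two compounds have the same atoms and bonds and differ only in configuration as drawn: 2 of 2 stereo elements differ (all stereocentres are inverted: mirror images); a stereocentre at a saturated ring carbon is drawn s in compound 3 and r in compound 4; a stereocentre at a saturated ring carbon is drawn s in compound 3 and r in compound 4), with the same atoms and bonds and a difference only in configuration as drawn: all stereocentres are inverted. Going by the values given here, no measured pair isolates such a change, so the data offer no direct precedent. Among the compounds with values here, the only guide is that compound 3 (200000 nM) sits within the scatter of two compounds that differ from it in structure. No step beyond the scatter is expected in this assay, in either direction. The expected step is a 1.1-fold lower number from compound 3 to compound 4 (0.05 log units; within the scatter) and it stays within the scatter. For compound 4 the estimated value is 180000 nM (expected range 100000 nM to 260000 nM).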

Compound 4, solubility: 200000 nM
The estimate for compound 4 lay 1.1-fold (0.05 log units) below the measured number; the range from low to high includes it.
By their numbers in this assay, from the lowest: compounds 2, 1, 3 and 4 (each within the scatter of the next).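

In this assay, inverting both stereocentres at the saturated ring gives no change at the digits printed from compound 3 to compound 4 (within the scatter). Going by these compounds alone, this is the first pair to isolate configuration, as the earlier compounds offered no measured step between structures differing in one place. At this position, the configuration as drawn therefore does not separate the two compounds in this assay, and the comparison can be read as one of configuration alone: the fact that compounds 3 and 4 differ only in the configuration as drawn.

This rests on a single pair of compounds, so it cannot be extended to the rest of the series. From the compounds shown here alone, whether configuration at the saturated ring remains equally silent when that ring carries a carboxylic acid or a longer chain remains open.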